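The compounds below may be only part of what the source reports. "The series", "measured", "known", "first", "only" and "open" are said of these compounds alone.

The compounds measured so far, each with its number in an assay on cells for antagonist activity at transient receptor potential cation channel subfamily V member 1 (Homo sapiens), read by FLIPR and calcium flux, with a stated time of 6 min; on this read-out higher numbers stand for weaker inhibition and lower numbers for stronger inhibition:

compound 1, `CC(C(=O)NCc1ccc(C(C)(C)C)nc1N1CCCC1)c1ccc(NS(C)(=O)=O)c(F)c1`, giving 1.2 nM
compound 2, `CCCCCCOc1nc(C(C)(C)C)ccc1CNC(=O)C(C)c1ccc(NS(C)(=O)=O)c(F)c1`, giving 2.7 nM
compound 3, `CC(C)COc1nc(C(C)(C)C)ccc1CNC(=O)C(C)c1ccc(NS(C)(=O)=O)c(F)c1`, giving 0.6 nM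

Compound 3 has the lowest number of the three. Its nearest neighbour is compound 1, and a 2.0-fold lower number from compound 1 to compound 3 (0.30 log units; within the scatter) stays within the scatter, so the two cannot be ranked against each other. The gap to compound 2 is wider: a 4.5-fold lower number from compound 2 to compound 3 (0.65 log units; beyond the scatter) lies beyond the scatter, and a 2.3-fold higher number from compound 1 to compound 2 (0.35 log units; beyond the scatter) also stands beyond it.

Compound 4, `CC(C(=O)NCc1ccc(C(C)(C)C)nc1OCc1ccccc1)c1ccc(NS(C)(=O)=O)c(F)c1`, differs from compound 3 by phenyl in place of isopropyl on a saturated chain carbon bound to an oxygen on an aromatic ring. Within the data shown here, the only measured step at the same place is the one from compound 2 to compound 3, where shortening pentyl to isopropyl brought the number down by a modest amount. Compound 4 moves the other way in size, exchanging a small branched chain for a ring of six carbons, a group larger than either isopropyl or pentyl. Among the measured compounds shown here, no measured compound carries an aromatic ring at this place, so the direction is a guess from size alone. A modest rise, that is weaker inhibition, is expected for compound 4, as a 2.5-fold higher number from compound 3 to compound 4 (0.40 log units; beyond the scatter). The estimate for compound 4 is 1.5 nM, with a range from 0.5 nM to 5 nM.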

Compound 4, inhibition constant: 4.4 nM
The estimate for compound 4 lay 2.9-fold (0.47 log units) below the measured number, within the range that was stated.
By their numbers in this assay, from the lowest: compounds 3 and 1 (each within the scatter of the next); then compounds 2 and 4 (each within the scatter of the next).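

In this assay the first aromatic ring at this place, on a saturated chain carbon bound to an oxygen on an aromatic ring, gives the widest gap seen so far: a 7.3-fold higher number from compound 3 to compound 4 (0.87 log units; beyond the scatter). Benzyloxy does not stand apart from hexyloxy, since a 1.6-fold higher number from compound 2 to compound 4 (0.21 log units; within the scatter) leaves that pair unranked even though phenyl and pentyl are very different groups, while a 3.7-fold higher number from compound 1 to compound 4 (0.56 log units; beyond the scatter) shows that benzyloxy also gives a higher number than pyrrolidin-1-yl. No measurement is available that accounts for these differences.

On these data alone, only isopropyl, pentyl and phenyl have been compared at this place, so it remains open whether the aromatic ring itself matters. Cyclohexyl in place of phenyl would test this, and methyl or ethyl would show how a shorter chain compares with isopropyl.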